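The source may report more compounds than this note shows. Statements on the series, on what has been measured and on what is new or still open speak of the compounds shown alone.

Compound 1 `Cc1nc(N(C)c2ccc([Se]C#N)c(C)c2)c2ccccc2n1` gives 9 nM in a functional assay on HepG2 cells (Homo sapiens) for inhibition, read by MTT assay, with a stated time of 48 h; a lower number here means a stronger inhibitor, a higher number a weaker inhibitor
Compound 2 `Cc1nc(N(C)c2ccc([Se]C#N)c(Cl)c2)c2ccccc2n1` gives 12 nM in this assay

The two values lie within the scatter of each other, so compound 2 cannot be ranked against compound 1 on these numbers alone. The next analogue is compound 3 `Cc1nc(N(C)c2ccc([Se]C#N)c(F)c2)c2ccccc2n1`, still unmeasured. It differs from compound 2 by fluoro in place of chloro on an aromatic carbon.

Within the data shown here, only one measured step bears on this change. It is chloro in place of methyl on an aromatic carbon, a 1.3-fold higher number from compound 1 to compound 2 (0.12 log units; within the scatter), and it stays within the scatter. Among the measured compounds shown here, no fluoro analogue has been measured yet, and a single step is thin evidence, so the range is kept wide. With that one step as the guide, no shift beyond the scatter is expected in this assay for this replacement.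

The expected step is a 1.1-fold higher number from compound 2 to compound 3 (0.03 log units; within the scatter), which is not expected to exceed the scatter. For compound 3 the estimated value is 13 nM, with an expected range from 6 nM to 30 nM in this assay.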

Compound 3, half-maximal inhibitory concentration: 37 nM
Compound 3: middle estimate off by 2.8-fold (0.45 log units), on the low side; measured number outside the range, above it.
By their numbers in this assay, from the lowest: compounds 1 and 2 (each within the scatter of the next); then compound 3.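

In this assay this position, ortho to a group of 3 heavy atoms and meta to a large group, turns out to respond to the choice of substituent: fluoro in place of chloro gives a 3.1-fold higher number from compound 2 to compound 3 (0.49 log units; beyond the scatter) and fluoro in place of methyl gives a 4.1-fold higher number from compound 1 to compound 3 (0.61 log units; beyond the scatter) and both steps lie beyond the scatter, while chloro and methyl could not be told apart. Among these three compounds fluoro alone separates from the others, and compound 3 is the weakest of the set, even though the change swaps one heavy atom for one heavy atom and leaves the counts of rings, hydrogen-bond donors, hydrogen-bond acceptors and net charge untouched. Nothing available accounts for this gap.

On these data alone, what bromo, methoxy, trifluoromethyl or an amine would give at this position remains open, and three groups are too few to tell whether fluoro is an isolated case or one end of a wider trend. As far as these compounds go, it is also open whether the fluoro step would hold on a compound with another group in place of the selenium-bearing nitrile.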